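This account rests on a few compounds, and the source may have more. Where it says the series, first, only, none or still open, it means among the compounds named here.

Measured so far:
- compound 1, `O=[N+]([O-])c1ccc(NCc2ccccc2O)cc1`: in a functional assay on Jurkat cells (Homo sapiens) for activation, with a stated time of 24 h (on this read-out lower numbers stand for an effect already at smaller amounts and higher numbers for an effect only at larger amounts of compound), compound 1 is recorded as "not active" (no number reported)
- compound 2, `Oc1ccccc1CNc1ccc(-c2ccc(F)cc2)cc1`: in this assay compound 2 gives 3860 nM

Compound 2 carries the only number shown in this assay; compound 1 contributes an entry without a number, so no step between measured compounds can be counted and nothing is yet known about the scatter-corrected size of any change in this series.

Compound 3, `Oc1ccccc1CNc1ccc(-c2cccc(Cl)c2)cc1`, is the next compound for this assay. It differs from compound 2 in one place: 3-chlorophenyl in place of 4-fluorophenyl on an aromatic carbon. Within the data shown here, with no measured step of this kind available, the change is expected to stay close to the value of compound 2, without a direction beyond the scatter. Compound 3 is estimated at 3500 nM in this assay, within 1200 nM to 10000 nM. The step this estimate means is a 1.1-fold lower number from compound 2 to compound 3 (0.04 log units; within the scatter), expected to fall within the usual scatter.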

Compound 3, half-maximal effective concentration: 6200 nM
Compound 3: the middle estimate sits 1.8-fold (0.25 log units) below what was measured, and the stated range covers the measured number.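

In this assay, among these compounds, the exchange on this aromatic carbon gives a 1.6-fold higher number from compound 2 to compound 3 (0.21 log units; within the scatter), the first step that can be read, so compound 2 and compound 3 cannot be told apart on this read-out. At this position, therefore, 3-chlorophenyl serves in place of 4-fluorophenyl with a measured number retained, although the two groups differ in both the halogen and its place on the ring, and this single step cannot separate those two changes. No measurement is available that would explain the result.

Still open, as far as these compounds go, is whether 4-chlorophenyl or 3-fluorophenyl would give a number within the scatter of these two compounds. Also open, from the compounds shown here alone, is how a group of another kind on this aromatic carbon, such as a carboxylic acid, an amine or a longer alkyl chain, would affect the number.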